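The source may report more compounds than this note shows. Statements on the series, on what has been measured and on what is new or still open speak of the compounds shown alone.

Compound 1, `COc1cc(-c2ncnn2-c2ccc(F)cc2)cc(OC)c1OC`: in a functional assay on A549 cells (Homo sapiens) for antiproliferative activity, read by MTT assay, with a stated time of 72 h (on this read-out higher numbers stand for weaker inhibition and lower numbers for stronger inhibition), compound 1 gives > 10000 nM, which is a limit of the assay and not a number.
Compound 2, `COc1cc(-c2ncnn2-c2ccc(Cl)cc2)cc(OC)c1OC`: in this assay compound 2 gives > 10000 nM, again a limit of the assay.
Compound 3, `COc1cc(-n2ncnc2-c2cccc(Cl)c2)cc(OC)c1OC`: in this assay compound 3 gives > 10000 nM, once more a limit of the assay.

All three measured compounds therefore sit at the limit of > 10000 nM in this assay, at which 3 of the 3 values shown sit, and none of them gives a readable number. The change from compound 2 to compound 1 is fluoro in place of chloro on an aromatic carbon. Its step, a step that the two limits leave unreadable from compound 2 to compound 1, cannot be read, since both ends are limits. Compound 3 has the same atoms as compound 2 joined differently; the difference between the two cores is not broken down here.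

The unmeasured compound 4, `COc1cc(-n2ncnc2-c2cccc(F)c2)cc(OC)c1OC`, is related to compound 3 by fluoro in place of chloro on an aromatic carbon. This is the same kind of change as that from compound 2 to compound 1, but not the same: in compound 1 the fluoro stands para to a large group, whereas in compound 4 it stands meta to a large group.

Because compound 3 gives > 10000 nM and compound 2 gives > 10000 nM with its partner compound 1 staying at the limit as well, compound 4 is expected to remain at the limit in this assay. The step from compound 3 to compound 4 is estimated as a step that the limit leaves unreadable from compound 3 to compound 4. Compound 4 is thus estimated at 15000 nM, most likely reported only as a limit, with a range from 8000 nM to 60000 nM.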

Compound 4, half-maximal inhibitory concentration: > 10000 nM
Compound 4 gave a limit, no number (the forecaster's own chance of this, stated with the estimate: 85%); the middle value is on the limit's open side.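

Within the data shown here, compound 3 and compound 4 both stay at a limit in this assay, so the change from chloro to fluoro between them gives no step that can be read. The whole set shown now rests at one limit: the limit of > 10000 nM in this assay, at which 4 of the 4 values shown sit.

The compounds shown leave open what number any of them would give in this assay, and whether the halogen change or the difference between the two cores shifts that number at all.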